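The source may report more compounds than this note shows. Statements on the series, on what has been measured and on what is new or still open speak of the compounds shown alone.

In a functional assay on HL-60 cells (Homo sapiens) for cytotoxicity, read by MTT assay, with a stated time of 24 h (on this read-out higher numbers stand for weaker inhibition and lower numbers for stronger inhibition), two compounds with the same core have been measured. Compound 1 `Nc1nn(Cc2cn(CC(=O)Nc3ccc(F)cc3)nn2)c2nc(-c3ccccc3)cc(C(F)(F)F)c12` gives 44.8 ug/mL. Compound 2 `Nc1nn(Cc2cn(CC(=O)Nc3c(F)cccc3F)nn2)c2nc(-c3ccccc3)cc(C(F)(F)F)c12` gives 32.8 ug/mL. Of the two numbers, compound 2 sits at the lower end, but a 1.4-fold lower number from compound 1 to compound 2 (0.14 log units; within the scatter) lies within the scatter, so the two cannot be told apart on this evidence.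

Compound 3 `Nc1nn(Cc2cn(CC(=O)Nc3ccccc3Br)nn2)c2nc(-c3ccccc3)cc(C(F)(F)F)c12` has not yet been measured. Its change from compound 2 is 2-bromophenyl in place of 2,6-difluorophenyl on an amide-type nitrogen. Going by the values given here, the only measured step that bears on it is the one on the same amide-type nitrogen, where a 1.4-fold lower number from compound 1 to compound 2 (0.14 log units; within the scatter) was a swap of one fluorine pattern for another that did nothing beyond the scatter. The new change also keeps a halogen-bearing phenyl ring on that nitrogen, trading two fluorines for one bromine. With just one small step to go on, there is no reason to expect more than the scatter, and the estimated step is a 1.1-fold higher number from compound 2 to compound 3 (0.03 log units; within the scatter). Compound 3 is therefore expected to give about 35 ug/mL, with a range from 15 ug/mL to 80 ug/mL.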

Compound 3, half-maximal inhibitory concentration: 27.2 ug/mL
Estimate against measurement, compound 3: 1.3-fold (0.11 log units) above, within the range that was stated.
By their numbers in this assay, from the lowest: compounds 3, 2 and 1 (each within the scatter of the next).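

In this assay the amide-type nitrogen has now carried three different halogen-bearing phenyl groups, and the numbers do not separate: 2-bromophenyl in place of 2,6-difluorophenyl gives a 1.2-fold lower number from compound 2 to compound 3 (0.08 log units; within the scatter) and 2-bromophenyl in place of 4-fluorophenyl gives a 1.6-fold lower number from compound 1 to compound 3 (0.22 log units; within the scatter) on this read-out. The earlier pair compared only two fluorine patterns, whereas these steps show that giving up fluorine for bromine also leaves no mark beyond the scatter, so among these three compounds neither the kind of halogen nor the number of halogens on the ring can be told apart. Nothing measured here offers a reason for this flat result.

All three groups are phenyl rings bearing fluorine or bromine, so the compounds shown leave open whether a phenyl ring with a methoxy group or an amine, or a plain alkyl chain in place of the ring, would move the number beyond the scatter. They also leave open whether a change elsewhere on the shared core, such as replacing the trifluoromethyl group with a methyl group, would do so.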